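The source may report more compounds than this note shows. Statements on the series, on what has been measured and on what is new or still open speak of the compounds shown alone.

Compound 1 `CC(OC(=O)Nc1ccccc1)c1cn2ncnc2s1` is the parent carbamate of the series. In a functional assay on CHO cells for antagonist activity at metabotropic glutamate receptor 5 (Homo sapiens), read by calcium flux (on this read-out lower numbers stand for stronger inhibition and higher numbers for weaker inhibition), compound 1 gives 10000 nM. Compound 2 `Cc1c(C(C)OC(=O)Nc2ccccc2)sc2ncnn12` carries a methyl in place of hydrogen on an aromatic carbon of the shared core. In this assay compound 2 reaches only > 31600 nM, which is a limit and not a number. The step of an at least 3.1-fold higher number from compound 1 to compound 2 (0.49 log units; beyond the scatter) is thus bounded by the limit of > 31600 nM in this assay, at which 1 of the 2 values shown sits, and compound 2 stands at the weak end of the two values shown. Compound 3 `Cc1c(C(C)OC(=O)Nc2cccnc2)sc2ncnn12` differs from compound 2 in one place: pyridin-3-yl in place of phenyl on an amide-type nitrogen. No measured step touches the group on the amide-type nitrogen; the only step shown, an at least 3.1-fold higher number from compound 1 to compound 2 (0.49 log units; beyond the scatter), concerns the core and does not bear on this change. No step beyond the scatter is expected in this assay for the exchange from compound 2 to compound 3. Compound 2 already rests at a limit, and the value of compound 3 is expected to come back as a limit more often than as a number. The estimate for compound 3 is 40000 nM, with a range from 10000 nM to 120000 nM. The estimated step that the limit leaves unreadable from compound 2 to compound 3 means no change beyond the scatter.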

Compound 3, half-maximal inhibitory concentration: 316 nM
Beside the measured number, compound 3's estimate is 130-fold (2.10 log units) above it, outside the stated range (below it).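

In this assay, among the compounds shown here, the group on the amide-type nitrogen, held as phenyl in the earlier compounds, proves to be a highly sensitive place: pyridin-3-yl in place of phenyl gives an at least 100-fold lower number from compound 2 to compound 3 (2.00 log units; beyond the scatter). The exchange leaves the heavy-atom count unchanged and adds one hydrogen-bond acceptor, and a single ring carbon replaced by nitrogen is thus enough for a large step on this methylated core, though these data do not show which feature of the pyridin-3-yl group is responsible. Compound 2 stands at a limit and not at a number, so this step gives only a bound on the true size of the change: the limit of > 31600 nM in this assay, at which 1 of the 3 values shown sits.

Going by these compounds, it remains open whether the methyl on the aromatic carbon of the core, which accounts for an at least 3.1-fold higher number from compound 1 to compound 2 (0.49 log units; beyond the scatter) with phenyl on the amide-type nitrogen, has a similar effect when pyridin-3-yl sits there. On these data alone, it also remains open whether the step depends on this particular pyridine attachment or extends to other groups on the amide-type nitrogen, such as pyridin-4-yl, pyrimidin-5-yl or a saturated piperidin-4-yl amine.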